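Swapping the amide-bound aryl in a receptor modulator series

The source may report more compounds than this note shows. Statements on the series, on what has been measured and on what is new or still open speak of the compounds shown alone.

Compound 1 `CS(=O)(=O)N1c2ccccc2CCC1C(=O)Nc1cccc(Cl)c1` is a small molecule tested in a functional assay on HEK293 cells for positive allosteric modulation of metabotropic glutamate receptor 5 (Rattus norvegicus), read by fluorescence and calcium flux (a lower number here means a smaller maximal response, a higher number a larger maximal response), where compound 1 reaches 60%. A second compound, compound 2 `Cn1cnc(S(=O)(=O)N2c3ccccc3CCC2C(=O)Nc2cccc(Cl)c2)c1`, differs only at the sulfonyl group, and in this assay compound 2 gives 75%. For the measured compounds named here, of these two numbers, compound 1 holds the lower one; the single measured step, a number 15 percentage points higher from compound 1 to compound 2 (beyond the scatter), lies beyond the scatter.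

Compound 3 `CS(=O)(=O)N1c2ccccc2CCC1C(=O)Nc1ccccn1` has not been measured. Relative to compound 1 the change is pyridin-2-yl in place of 3-chlorophenyl on an amide-type nitrogen. Going by the values given here, the one measured step concerns the sulfonyl substituent, not the amide-bound ring, so no measured step bears directly on this change, and the two measured values offer no guide to its direction.

With nothing to anchor it, the expectation for compound 3 rests on compound 1 alone and carries a wide range: compound 3 is estimated to give 55% in this assay, within 30% to 80%. That estimate corresponds to an expected step of a number 5 percentage points lower from compound 1 to compound 3 (within the scatter), which is within the scatter.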

Compound 3, largest response reached (Emax), in percent of the reference or control that the assay uses: 68%
Compound 3: middle estimate off by 13 percentage points, on the low side; measured number inside the range.
By their numbers in this assay, from the lowest: compounds 1, 3 and 2 (each within the scatter of the next, the first and the last beyond it).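

Putting pyridin-2-yl in place of 3-chlorophenyl on the amide-type nitrogen gives a number 8 percentage points higher from compound 1 to compound 3 (within the scatter) in this assay and so leaves the two compounds indistinguishable in this read-out. For the compounds shown here, this is the first look at the amide-bound ring, as the earlier step concerned only the sulfonyl group. It shows that, on the core of compound 1, a ring of carbon only that carries chlorine can be exchanged for a ring with one hetero atom and a hydrogen-bond acceptor without a change in maximal response that rises above the scatter. Nothing in the data explains why these two rings give results this close.

With one swap, the loss of the chlorine cannot be separated from the gain of the ring nitrogen, and a plain phenyl or a pyridin-3-yl on the same nitrogen would be needed to pull these two apart. Also open, from the compounds shown here alone, is whether the sulfonyl change behind a number 15 percentage points higher from compound 1 to compound 2 (beyond the scatter) would carry over to a compound with pyridin-2-yl on the amide-type nitrogen.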